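The compounds below may be only part of what the source reports. "The series", "measured", "known", "first", "only" and "open" are said of these compounds alone.

Three cinnamamides carrying different chains on the amide nitrogen have been measured. Compound 1 `CCCCCCCCCCNC(=O)/C=C/c1ccccc1` gives 15% in a functional assay on the whole organism for inhibition, with Brassica rapa subsp. chinensis as the target, with a stated time of 3 days, tested at 100 ppm; on this read-out higher numbers stand for more inhibition of growth at the one concentration tested and lower numbers for less inhibition of growth. Compound 2 `CC(C)CNC(=O)/C=C/c1ccccc1` gives 78% in this assay, and compound 3 `CCCCCNC(=O)/C=C/c1ccccc1` gives 76% in this assay. Compound 3 stands second highest of the three, with compound 2 within the scatter of it and compound 1 far below it.

Compound 4 `CCCNC(=O)/C=C/c1ccccc1` is not yet measured. It differs from compound 3 in one place: hydrogen in place of ethyl on a saturated chain carbon, three bonds along the chain from an amide-type nitrogen.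

Among the measured compounds shown here, two measured steps bear on the chain on the nitrogen. Shortening the chain by a large amount gave a number 61 percentage points higher from compound 1 to compound 3 (beyond the scatter), while the change from isobutyl to pentyl gave a number 2 percentage points lower from compound 2 to compound 3 (within the scatter). The shortening to propyl is a smaller change of the same kind as the first step, and the second step shows that chains of roughly this length sit at the same level. No step beyond the scatter is therefore expected in this assay, and compound 4 is expected to give about 75%, within 55% to 90%, which means an expected step of a number 1 percentage points lower from compound 3 to compound 4 (within the scatter).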

Compound 4, percent growth inhibition at one concentration: 63%
Estimate against measurement, compound 4: 12 percentage points above, and the stated range covers the measured number.
By their numbers in this assay, from the lowest: compound 1; then compound 4; then compounds 3 and 2 (each within the scatter of the next).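

In this assay the level does not hold at the propyl chain. Hydrogen in place of ethyl, three bonds along the chain from an amide-type nitrogen, gives a number 13 percentage points lower from compound 3 to compound 4 (beyond the scatter), which ends the flat stretch that the pentyl and isobutyl chains suggested. Hydrogen in place of methyl on a saturated chain carbon bound to two saturated chain carbons gives a number 15 percentage points lower from compound 2 to compound 4 (beyond the scatter) in the same direction, while hydrogen in place of heptyl gives a number 48 percentage points higher from compound 1 to compound 4 (beyond the scatter) so that, among these four compounds, the number falls on both sides of the pentyl and isobutyl chains. Nothing on hand accounts for this drop at propyl.

Open, from the compounds shown here alone, is where between the pentyl chain and the decyl chain the number collapses, and whether a hexyl or octyl chain keeps the level of compound 3. Also open, going by these compounds, is whether an ethyl or methyl chain on the nitrogen continues the fall seen with propyl.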